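A few compounds are considered here, and "the series" means these few. Any claim that something is new, unique, unknown or untested is made for them only; others in the source may bear on it.

Of the compounds shown here, three built on one shared core have been measured in a functional assay (aorta) with Rattus norvegicus as the target; on this read-out higher numbers stand for higher potency (the scale is a negative logarithm) and lower numbers for lower potency. Compound 1 `CC1(C)C=C(n2ccccc2=O)c2cc(C(=O)c3cccs3)ccc2O1` gives 6.4 in this assay. Compound 2 `CC1(C)C=C(n2ccccc2=O)c2cc(C(=O)c3ccc([N+](=O)[O-])cc3)ccc2O1` gives 6.2 in this assay. Compound 3 `CC1(C)C=C(n2ccccc2=O)c2cc(OCC(=O)c3ccccc3)ccc2O1` gives 5.05 in this assay, and it stands lowest of the three numbers; compound 2 is nearest to it and compound 1 furthest, both beyond the scatter.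

The next compound, compound 4 `CC1(C)C=C(n2ccccc2=O)c2cc(OC(=O)Nc3ccc(F)cc3)ccc2O1`, differs from compound 3 in one place: (4-fluorophenyl)carbamoyl in place of benzoylmethyl on an oxygen on an aromatic ring

Going by the values given here, only one measured step exists, a number 0.20 log units lower from compound 1 to compound 2 (within the scatter), and it concerns a change of the aryl group on a carbonyl carbon, not a change at the aromatic oxygen; it therefore bears on compound 4 only loosely, showing that a swap of one aromatic ring for another at a neighbouring position left this assay essentially unchanged. Among the compounds with values here, no measured pair shows what a carbamoyl group in place of a benzoylmethyl group on the aromatic oxygen does. Compound 4 is therefore expected to stay near compound 3, with the step of a number 0.25 log units higher from compound 3 to compound 4 (within the scatter) estimated to lie within the scatter. Compound 4 is estimated at 5.3, within a range from 4.6 to 6.2.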

Compound 4, logarithm of the reciprocal of the active concentration, log(1/C): 5.3
Beside the measured number, compound 4's estimate shows no gap at the digits printed, and the stated range covers the measured number.
By their numbers in this assay, from the lowest: compounds 3 and 4 (each within the scatter of the next); then compounds 2 and 1 (each within the scatter of the next).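

In this assay, going by these compounds alone, (4-fluorophenyl)carbamoyl in place of benzoylmethyl on an oxygen on an aromatic ring gives a number 0.25 log units higher from compound 3 to compound 4 (within the scatter), and this is the first reading of a change at this place. The exchange swaps one group carrying a six-membered aromatic ring for another, but the entering group also brings a nitrogen, a fluorine and a hydrogen-bond donor that the leaving group lacks, and the read-out registers no change beyond the scatter, so these differences together leave no visible mark on this pair. No measurement in hand speaks to the reason for this result.

The compounds shown leave open whether this oxygen would hold the same level with a group that has no aromatic ring, such as a methyl, a longer alkyl chain, or a chain ending in an amine or a carboxylic acid. They also leave open what the fluorine itself contributes, since a comparison with plain phenylcarbamoyl or with 4-chlorophenylcarbamoyl on the same oxygen would be needed to separate it from the carbamoyl link.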